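A few compounds are considered here, and "the series" means these few. Any claim that something is new, unique, unknown or untested is made for them only; others in the source may bear on it.

Compound 1 `CC1CC/C(=N\Nc2ccc(O)cc2)c2ncc(C(=O)O)c(=O)n21` and compound 2 `CC1CC/C(=N\Nc2ccc(C(F)(F)F)cc2)c2ncc(C(=O)O)c(=O)n21` share one core and differ in a single group. In a functional assay on the whole organism for inhibition, with Rattus norvegicus as the target (a lower number here means that less compound is needed, a higher number that more compound is needed for the effect), compound 1 gives only a limit of the assay, > 100 umol/kg. In this assay compound 2 also gives only a limit, > 1000 umol/kg. The step that the two limits leave unreadable from compound 1 to compound 2 therefore has no readable size. Compound 3 `CC1CC/C(=N\Nc2ccc([N+](=O)[O-])cc2)c2ncc(C(=O)O)c(=O)n21` differs from compound 2 by nitro in place of trifluoromethyl on an aromatic carbon. Among the measured compounds shown here, no measured step bears on this change, and both known compounds sit at limits. Compound 3 is therefore expected to sit near the limit as well, estimated at 1000 umol/kg (range 300 umol/kg to 3000 umol/kg), an expected step of a number no higher from compound 2 to compound 3 (the limit leaves the size open) that the scatter could not separate from none.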

Compound 3, dose for 50% inhibition: > 320 umol/kg
Compound 3 ended at the assay's limit; the forecaster's own chance of this, stated with the estimate: 80%; the middle value lies beyond the limit too.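

In this assay compound 3 gives only a limit, > 320 umol/kg. The steps among compound 1, compound 2 and compound 3 cannot be read. The compounds shown leave open whether hydroxy, trifluoromethyl or nitro changes the dose needed at all.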